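A few compounds are considered here, and "the series" means these few. Any claim that something is new, unique, unknown or untested is made for them only; others in the source may bear on it.

Measured in a functional assay on NCI-H1975 cells (Homo sapiens) for antiproliferative activity; a higher number here means a weaker inhibitor, a lower number a stronger inhibitor:
Compound 1 `Cc1c2c(n3c1CCNC[C@@H](C)[C@H](C)Nc1cc-3ccc1C(N)=O)CC(C)(C)CC2=O`: 27 nM
Compound 2 `Cc1c2c(n3c1CCCN(C)[C@@H](C)[C@H](C)Nc1cc-3ccc1C(N)=O)CC(C)(C)CC2=O`: 69 nM
Compound 3 `Cc1c2c(n3c1CCN(C)C[C@@H](C)[C@H](C)Nc1cc-3ccc1C(N)=O)CC(C)(C)CC2=O`: 27 nM

Compound 2, at 69 nM, has the highest number of the three, and its gaps to compound 1 and compound 3 both lie beyond the scatter. Compound 4 `Cc1c2c(n3c1CCCN(C(=O)CO)[C@@H](C)[C@H](C)Nc1cc-3ccc1C(N)=O)CC(C)(C)CC2=O` carries (hydroxymethyl)carbonyl in place of methyl on an amine nitrogen in a ring of compound 2, and the change counts as (hydroxymethyl)carbonyl in place of methyl on an amine nitrogen in a ring.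

Going by the values given here, one measured step bears on this, a methyl in place of hydrogen on an amine nitrogen in a ring: no change at the digits printed from compound 1 to compound 3 (within the scatter). Among the compounds with values here, that step is only a partial guide, since no measured compound carries (hydroxymethyl)carbonyl. With so little evidence, no step beyond the scatter is expected in this assay, though the uncertainty runs wide in both directions. The expected change is a 1.2-fold higher number from compound 2 to compound 4 (0.06 log units; within the scatter). The estimated value for compound 4 is 80 nM. The expected range for compound 4 runs from 22 nM to 300 nM.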

Compound 4, half-maximal inhibitory concentration: 54 nM
Compound 4: middle estimate off by 1.5-fold (0.17 log units), on the high side, and the stated range covers the measured number.
By their numbers in this assay, from the lowest: compounds 1, 3, 4 and 2 (each within the scatter of the next, the first and the last beyond it).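

In this assay, (hydroxymethyl)carbonyl in place of methyl on this amine nitrogen gives a 1.3-fold lower number from compound 2 to compound 4 (0.11 log units; within the scatter), so a group of 4 heavy atoms, with 1 hydrogen-bond donor and 2 hydrogen-bond acceptors, leaves the number where methyl had it. Going by these compounds alone, the earlier step, no change at the digits printed from compound 1 to compound 3 (within the scatter), covered only methyl in place of hydrogen, so this is the first sign that a larger group bearing a carbonyl can sit on a ring amine nitrogen without a step beyond the scatter.

Going by these compounds, whether a plain acetyl group, a longer chain ending in a hydroxyl, or a carbonyl group carrying an amine or a carboxylic acid would behave the same on this nitrogen stays open. Nothing at hand explains why the number holds through this change.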